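Selenium Out, Methylsulfanyl In: Expected Cytotoxicity

A few compounds are considered here, and "the series" means these few. Any claim that something is new, unique, unknown or untested is made for them only; others in the source may bear on it.

Compound 1 `COc1ccc(CNc2nc([SeH])nc3ccccc23)cc1` carries a selenium atom on its shared core. In an ADME assay on BEAS-2B cells (Homo sapiens) for cytotoxicity, read by MTT assay, with a stated time of 72 h (on this read-out higher numbers stand for weaker inhibition of growth and lower numbers for stronger inhibition of growth), compound 1 gives 37400 nM. Compound 2 `CSc1nc(NCCCCCO)c2ccccc2n1`, which carries a methylsulfanyl group on the same core with a different side chain, gives 39300 nM in this assay. These two numbers differ only within the usual scatter of repeated measurements, so compound 1 stands alongside compound 2 rather than apart from it. A third compound, compound 3 `[SeH]c1nc([SeH])c2ccccc2n1`, carries selenium at two positions, but in this assay compound 3 gives only "not determined" (no result reported), so no number was reported for it.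

Compound 4 `COc1ccc(CNc2nc(SC)nc3ccccc23)cc1` has not yet been measured. It differs from compound 1 in one place: a group of 2 heavy atoms (1 carbon, 1 sulfur; no ring) in place of one selenium atom, on an aromatic carbon. Among the compounds with values here, no pair of measured compounds differs in exactly this way, so the effect of the change cannot be read off directly. Within the data shown here, what the data do show is that compound 2, the only measured compound with a methylsulfanyl group, gives 39300 nM, close to compound 1. On that basis the step in this assay is expected to be small, with no direction beyond the scatter, as a 1.1-fold higher number from compound 1 to compound 4 (0.03 log units; within the scatter) expresses. Compound 4 is therefore estimated at 40000 nM, with a range from 18000 nM to 90000 nM.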

Compound 4, concentration for 50% growth inhibition: 21700 nM
Compound 4: middle estimate off by 1.8-fold (0.27 log units), on the high side, and the stated range covers the measured number.
By their numbers in this assay, from the lowest: compounds 4, 1 and 2 (each within the scatter of the next).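

In this assay the exchange of the selenium atom for a methylsulfanyl group, on the aromatic carbon between two ring nitrogen atoms, gives a 1.7-fold lower number from compound 1 to compound 4 (0.24 log units; within the scatter) and so stays within the usual scatter of repeated measurements. Within the data shown here, this is the first comparison at this position with the rest of the molecule held the same, which compound 2, with its different side chain, could not provide. On this read-out, with this side chain, selenium at this position and the methylsulfanyl group cannot be told apart, and no measurement shown explains this result.

From the compounds shown here alone, it remains open whether other groups at this position, such as an amine, a hydroxyl group or a longer chain like ethylsulfanyl, would also stay within the scatter or would move the number clearly in either direction. Among these compounds, it is also open whether the same exchange would give a similarly small step on a different side chain, such as the one carried by compound 2.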